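Swapping the Sulfonyl Substituent in an Acyl Sulfonamide Series

The compounds below may be only part of what the source reports. "The series", "measured", "known", "first", "only" and "open" are said of these compounds alone.

Measured compounds:
compound 1 `CC(C)(C)CNCCS(=O)(=O)NC(=O)c1ccc(Nc2nc(NC3(c4ccc(Cl)cc4)CC3)nc(OCC(F)(F)F)n2)cc1` gives 90%
compound 2 `CNC(=O)NCCS(=O)(=O)NC(=O)c1ccc(Nc2nc(NC3(c4ccc(Cl)cc4)CC3)nc(OCC(F)(F)F)n2)cc1` gives 100%

Both measured compounds share one core and differ only in the group on the sulfonyl sulfur. In an ADME assay on microsomes from liver (Rattus norvegicus) for metabolic stability, with a stated time of 10 min (a lower number here means that less of the compound is left, a higher number that more of the compound is left), compound 2 gives 100%; this is the higher of the two numbers, but the step of a number 10 percentage points higher from compound 1 to compound 2 (within the scatter) is within the scatter, so the two compounds cannot be told apart on these data.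

Compound 3 `Cc1ccccc1S(=O)(=O)NC(=O)c1ccc(Nc2nc(NC3(c4ccc(Cl)cc4)CC3)nc(OCC(F)(F)F)n2)cc1` is not yet measured. Its change from compound 2 is 2-methylphenyl in place of 2-((methylcarbamoyl)amino)ethyl on a sulfonyl sulfur. Within the data shown here, the only measured step, from compound 1 to compound 2, exchanged one alkyl group on an amine nitrogen for another and did not move the readout beyond the scatter. The change to compound 3 is of a different kind, so that step bears on it only loosely: it shows that the shared core is nearly fully retained regardless of the side chain tested so far. Compound 3 is therefore expected to stay near the measured pair, with a step of a number 15 percentage points lower from compound 2 to compound 3 (beyond the scatter) that is estimated to be small; the expected value for compound 3 is 85%, within 60% to 100%.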

Compound 3, percent of the compound remaining: 100%
The estimate for compound 3 lay 15 percentage points below the measured number; low and high end bracket the measured number.
By their numbers in this assay, from the lowest: compounds 1, 2 and 3 (each within the scatter of the next).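

Until now, the sulfonyl sulfur had carried only ethyl chains with a nitrogen-containing end, so the tolerance of this position had been tested only within that type of group. Compound 3 replaces such a chain with 2-methylphenyl, a six-membered aromatic ring of carbon only with 0 hydrogen-bond donors, and this assay shows no change at the digits printed from compound 2 to compound 3 (within the scatter) and a number 10 percentage points higher from compound 1 to compound 3 (within the scatter). Thus, a chain and an aromatic ring on this sulfur cannot be told apart in this read-out, and no supporting measurement offers an explanation for that result.

Among these compounds, the three compounds leave open whether any group on the sulfonyl sulfur can move the number beyond the scatter, since together they show no step of that size. An unsubstituted phenyl ring, a pyridine ring, a carboxylic acid or a longer alkyl chain at this position could show how far this tolerance extends, and whether it depends on the methyl group of 2-methylphenyl.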